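A few compounds are considered here, and "the series" means these few. Any claim that something is new, unique, unknown or untested is made for them only; others in the source may bear on it.

Of the compounds shown here, two have been tested in a functional assay on the whole organism (strain Wister albino) for inhibition, with Rattus norvegicus as the target, read by paw edema, with stated times of 1 h and 2 h, at a dose of 50 mg/kg by the intraperitoneal route; a lower number here means less inhibition, a higher number more inhibition at the dose given (going by the name of the read-out). Compound 1, with the structure `CN1C[C@@H](c2ccc(Cl)cc2)[C@@]2(Cc3ccccc3C2=O)[C@@]12C(=O)Nc1ccccc12`, gives 28.4% in this assay. Compound 2, with the structure `COc1ccc([C@@H]2CN(C)[C@]3(C(=O)N(C)c4ccccc43)[C@]23Cc2ccccc2C3=O)cc1`, gives 20.2% in this assay. Among the measured compounds shown here, these two numbers differ by less than the usual scatter of such measurements, so the data do not show one of them to inhibit paw edema more than the other; compound 2 simply carries the lower of the two figures, and compound 1 is its only comparison.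

Compound 3, with the structure `COc1ccc([C@@H]2CN(C)[C@]3(C(=O)Nc4ccccc43)[C@]23Cc2ccccc2C3=O)cc1`, has not yet been measured. It is built from compound 2 by one change: hydrogen in place of methyl on an amide-type nitrogen in a ring. Compound 1 also carries a hydrogen at this amide-type nitrogen, but it differs from compound 2 in a second place as well, so no single-change comparison exists for this swap, and no shown step tells what it does.

For the measured compounds named here, with only two measured numbers, both within scatter of each other, the expected step from compound 2 to compound 3 in this assay is a number 3.8 percentage points higher from compound 2 to compound 3 (within the scatter), that is, nothing beyond the scatter. Compound 3 is therefore estimated to give 24%, within a range of 12% to 36%.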

Compound 3, a percentage reported as inhibition, in the whole organism at one dose (the size of the read-out at that dose, not a potency): 17.5%
Beside the measured number, compound 3's estimate is 6.5 percentage points above it; measured number inside the range.
By their numbers in this assay, from the lowest: compounds 3, 2 and 1 (each within the scatter of the next, the first and the last beyond it).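

Replacing methyl with hydrogen on the amide-type nitrogen now has a direct reading in this assay as a number 2.7 percentage points lower from compound 2 to compound 3 (within the scatter) and so, at this dose, the two groups cannot be told apart at this position. Among the compounds shown here, with the amide hydrogen held the same, methoxy in place of chloro on an aromatic carbon gives a number 10.9 percentage points lower from compound 1 to compound 3 (beyond the scatter) and this modest step is the first to go beyond the usual scatter, which suggests that the aromatic carbon matters more here than the amide-type nitrogen, at least across these three compounds. Nothing measured here offers a reason for either step.

From the compounds shown here alone, whether a longer chain such as ethyl, or an acetyl group, on the amide-type nitrogen would read differently remains open, as does the outcome of fluoro or a dimethylamino group on the aromatic carbon. It is also unknown whether the swap of chloro for methoxy would have a step of the same size with methyl on the nitrogen, and a reading at one dose says nothing about potency.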